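Cytotoxicity Limits in Three Compounds and a Fourth Expected

The source may hold more compounds than are shown below. What is called first, only, known or untested is meant among the compounds shown, and "the series" means these compounds.

Compound 1 `Cc1ccc2[nH]c(=O)c(CN(Cc3cccc(F)c3)Cc3ccc4ccccc4c3)cc2c1` — in a toxicity assay on MDCK cells (Canis lupus familiaris) for cytotoxicity, read by crystal violet staining, with a stated time of 48 h (on this read-out lower numbers stand for higher toxicity in this test and higher numbers for lower toxicity in this test), compound 1 gives > 5000 nM, a limit of the assay.
Compound 2 `Cc1ccc2cc(CN(Cc3ccc(C(C)(C)C)cc3)C3CCCC3)c(=O)[nH]c2c1` — in this assay compound 2 gives > 10000 nM, a limit of the assay.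
Compound 3 `Cc1ccc2[nH]c(=O)c(CN(Cc3ccc(OCC(=O)O)cc3)Cc3ccc(C(C)(C)C)cc3)cc2c1` — in this assay compound 3 gives > 10000 nM, a limit of the assay.

None of the three measured compounds reaches a numerical value in this assay. Two of them sit at the limit of > 10000 nM in this assay, at which 2 of the 3 values shown sit, and the remaining one sits at the limit of > 5000 nM in this assay, at which 1 of the 3 values shown sits. For the measured compounds named here, compound 3 therefore stands, like its companions, at the upper limit of what this assay reports, and no step between measured compounds is available to compare.

Compound 4 `Cc1ccc2[nH]c(=O)c(CN(Cc3ccc(C(C)(C)C)cc3)[C@@H](C)c3ccc(F)cc3)cc2c1` differs from compound 3 in one place: 1-(4-fluorophenyl)ethyl in place of 4-(carboxymethoxy)benzyl on an amine nitrogen. Going by the values given here, since compound 3 offers only a limit and no measured step is at hand, no change beyond the scatter is expected from compound 3 to compound 4 in this assay; the step is estimated as a number no higher from compound 3 to compound 4 (the limit leaves the size open). On this basis compound 4 is expected to give about 10000 nM in this assay, estimated to lie between 3000 nM and 30000 nM, most likely again reported only as a limit.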

Compound 4, half-maximal cytotoxic concentration: > 5000 nM
Compound 4: only a limit was reported (the forecaster's own chance of this, stated with the estimate: 75%); the middle value lies beyond the limit too.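

In this assay compound 3 gives > 10000 nM, a limit of the assay. For the compounds shown here, compound 4 gives > 5000 nM, also a limit, so no step between compound 3 and compound 4 can be read. The compounds shown leave open at what concentration, if any, either becomes cytotoxic.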